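The source may hold more compounds than are shown below. What is called first, only, known or untested is meant among the compounds shown, and "the series" means these compounds.

In a functional assay on MCF7 cells (Homo sapiens) for inhibition, read by MTT assay, with a stated time of 72 h (on this read-out higher numbers stand for weaker inhibition and lower numbers for stronger inhibition), compound 1 (`COc1cc(NC(=O)/C=C/c2cccc(OCc3ccccc3)c2)cc(OC)c1OC`) gives 2400 nM while compound 2 (`C=C(Br)C(=O)Nc1cccc(/C=C/C(=O)Nc2cccc(F)c2)c1`) gives 3300 nM and compound 3 (`C=C(Br)C(=O)Nc1cccc(/C=C/C(=O)Nc2ccc(F)c(F)c2)c1`) gives 2690 nM as its value. Compound 3 lies within the scatter of both other compounds, so the numbers set no order among them. Among the measured compounds shown here, the only measured step (a 1.2-fold lower number from compound 2 to compound 3 (0.09 log units; within the scatter)) is fluoro in place of hydrogen on an aromatic carbon, and it stays within the scatter.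

Compound 4 (`C=C(Br)C(=O)Nc1cccc(/C=C/C(=O)NCc2ccc(C)cc2)c1`) differs from compound 3 by 4-methylbenzyl in place of 3,4-difluorophenyl on an amide-type nitrogen. For the measured compounds named here, the fluoro step covers only a small part of this change, and no measured pair replaces the whole group on that nitrogen, so it is a weak guide. From the compounds shown here alone, no step beyond the scatter is therefore expected in this assay for now, and either direction remains open. The expected change (a 1.1-fold higher number from compound 3 to compound 4 (0.05 log units; within the scatter)) is small against the wide uncertainty. For compound 4 the estimated value is 3000 nM with an expected range from 1000 nM to 9000 nM on this read-out.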

Compound 4, half-maximal inhibitory concentration: 2200 nM
Estimate against measurement, compound 4: 1.4-fold (0.13 log units) above; measured number inside the range.
By their numbers in this assay, from the lowest: compounds 4, 1, 3 and 2 (each within the scatter of the next).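

In this assay, the full exchange on the amide-type nitrogen gives a 1.2-fold lower number from compound 3 to compound 4 (0.09 log units; within the scatter) for 4-methylbenzyl in place of 3,4-difluorophenyl, and a 1.5-fold lower number from compound 2 to compound 4 (0.18 log units; within the scatter) for 4-methylbenzyl in place of 3-fluorophenyl. The earlier step covered only a fluoro exchange on the aromatic ring, whereas these two steps replace the whole group on that nitrogen, including the removal of all fluorine, and still produce no change beyond the scatter. No supporting data bear on why the values stay this close.

From the compounds shown here alone, every step read so far lies within the scatter, so it remains open whether any group at this position can shift the number beyond it. An amine, a carboxylic acid or a longer chain ending in the aromatic ring would test this, and the shared core of compounds 2, 3 and 4 stays unprobed.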